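Cytotoxicity of a Bridged Amine Ester Series on Rat Myoblasts

The compounds below may be only part of what the source reports. "The series", "measured", "known", "first", "only" and "open" are said of these compounds alone.

Measured compounds:
compound 1 `O=C(CN1CCCC1)OC1CC2(N3CCCCC3)CC(c3ccccc3)C1C(c1ccccc1)C2` — 16400 nM
compound 2 `CCN(CC)CC(=O)OC1CC2(N3CCCCC3)CC(c3ccccc3)C1C(c1ccccc1)C2` — 23900 nM

In an ADME assay on L6 cells (Rattus norvegicus) for cytotoxicity, read by resazurin assay, with a stated time of 72 h (on this read-out lower numbers stand for stronger inhibition and higher numbers for weaker inhibition), compound 1 gives 16400 nM, the lowest of the two numbers obtained so far. Its nearest neighbour is compound 2, which in this assay gives 23900 nM; the step of a 1.5-fold higher number from compound 1 to compound 2 (0.16 log units; within the scatter) lies within the scatter, so the two compounds cannot be told apart on this read-out.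

Compound 3 `CN(C)C12CC(OC(=O)CN3CCCC3)C(C(c3ccccc3)C1)C(c1ccccc1)C2` has not yet been measured. It differs from compound 1 in one place: dimethylamino in place of piperidin-1-yl on a saturated ring carbon. For the measured compounds named here, the only measured step, a 1.5-fold higher number from compound 1 to compound 2 (0.16 log units; within the scatter), concerns the amine on the chain bound to the carbonyl carbon, not the amine on the saturated ring carbon, so it bears on the new change only by analogy: an exchange of one small saturated amine for another left the number essentially unchanged. On that basis no step beyond the scatter is expected for compound 3 in this assay, the estimated step being a 1.1-fold higher number from compound 1 to compound 3 (0.04 log units; within the scatter). Compound 3 is therefore expected to give about 18000 nM, with a likely range from 8000 nM to 40000 nM.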

Compound 3, half-maximal inhibitory concentration: 32700 nM
Compound 3: middle estimate off by 1.8-fold (0.26 log units), on the low side, within the range that was stated.
By their numbers in this assay, from the lowest: compounds 1, 2 and 3 (each within the scatter of the next).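

At the saturated ring carbon, the compounds now show a change to the amine on the ring itself rather than the one on the chain. In this assay, dimethylamino in place of piperidin-1-yl gives a 2.0-fold higher number from compound 1 to compound 3 (0.30 log units; within the scatter), so this read-out does not separate the two compounds even though the exchange removes a six-membered non-aromatic ring and puts a group of 3 heavy atoms where one of 6 heavy atoms stood, with the count of hydrogen-bond acceptors unchanged. No evidence is available that could explain the size of this step.

As far as these compounds go, what a morpholin-4-yl group, a primary amine or a carboxylic acid would do on this saturated ring carbon remains open, as the two amines compared here are both tertiary and uncharged as drawn, and neither takes the number beyond the scatter. From the compounds shown here alone, it is also open whether the two amine sites act independently, which a compound carrying diethylamino on the chain together with dimethylamino on the ring carbon, compared with compound 2 and compound 3, would begin to show.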